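Swapping a Hydroxy for a Nitro on an Indanone Scaffold

The compounds below may be only part of what the source reports. "The series", "measured", "known", "first", "only" and "open" are said of these compounds alone.

Of the compounds shown here, two built on the same benzylidene-indanone core have been tested for their ability to slow the growth of prostate cancer cells. Compound 1 `COc1cc2c(c(OC)c1OC)C/C(=C\c1cc(OC)c(OC)c(OC)c1OC)C2=O` carries methoxy groups on both rings. In a functional assay on PC-3 cells (Homo sapiens) for antiproliferative activity, read by MTT assay, with a stated time of 48 h (on this read-out higher numbers stand for weaker inhibition of growth and lower numbers for stronger inhibition of growth), compound 1 gives > 10000 nM, which is a limit of the assay rather than a number. Compound 2 `COc1ccc(/C=C2\Cc3cc(OC)c(OC)c(OC)c3C2=O)cc1O` carries a hydroxy group and a methoxy group on its pendant ring. In this assay compound 2 gives > 10000 nM, again a limit and not a measured number. Both values therefore sit at the same boundary (the limit of > 10000 nM in this assay, at which 2 of the 2 values shown sit), so neither compound can be ranked against the other; compound 2 stands only as a limit.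

Compound 3 `COc1ccc(/C=C2\Cc3cc(OC)c(OC)c(OC)c3C2=O)cc1[N+](=O)[O-]` is the unmeasured analogue, differing from compound 2 in one place: nitro in place of hydroxy on an aromatic carbon. Going by the values given here, no measured step exists between any pair here, so the size of the step from compound 2 to compound 3 in this assay is uncertain; the expectation is for a change no larger than the scatter, with a fair chance that a limit is reported again. Compound 3 is estimated at 15000 nM, with a range from 3000 nM to 60000 nM, an expected step that the limit leaves unreadable from compound 2 to compound 3.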

Compound 3, concentration for 50% growth inhibition: > 10000 nM
Compound 3 was reported as a limit; the forecaster's own chance of this, stated with the estimate: 60%; the middle value does not contradict the limit.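

Compound 3 also stands only as a limit, just as compound 2 does, so the change from hydroxy to nitro gives no step that can be read between them: the limit of > 10000 nM in this assay, at which 3 of the 3 values shown sit.

The compounds shown leave open how they rank against one another in this assay, and which change to the shared core, if any, would bring a value inside the range of the assay.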